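Compound 3 to compound 4: exchanging the five-membered aromatic ring

This account rests on a few compounds, and the source may have more. Where it says the series, first, only, none or still open, it means among the compounds named here.

In an ADME assay on HEK293 cells (Homo sapiens) for cytotoxicity, read by ATP content, with a stated time of 6 h (a lower number here means that less compound is tolerated, a higher number that more compound is tolerated), compound 1 `CCC(O)CNc1nc(N)nc2ccn(Cc3ccccn3)c12` gives > 24000 nM as a limit. Compound 2 `CC(Nc1nc(N)nc2ccn(Cc3ccccn3)c12)c1ccccn1` gives > 24000 nM as a limit too. Compound 3 `Cc1nc(CNc2nc(N)nc3ccn(Cc4ccccn4)c23)cs1` gives > 24000 nM as a limit as well. All three rest on the limit of > 24000 nM in this assay, at which 3 of the 3 values shown sit, and no number places compound 3 among them.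

Compound 4 `Cc1nnc(CNc2nc(N)nc3ccn(Cc4ccccn4)c23)o1` carries 5-methyl-1,3,4-oxadiazol-2-yl in place of 2-methyl-1,3-thiazol-4-yl on a saturated chain carbon bound to a nitrogen on an aromatic ring. The difference 5-methyl-1,3,4-oxadiazol-2-yl in place of 2-methyl-1,3-thiazol-4-yl on a saturated chain carbon bound to a nitrogen on an aromatic ring leaves the shared core untouched.

Bearing on this change are a step that the two limits leave unreadable from compound 1 to compound 3 and a step that the two limits leave unreadable from compound 2 to compound 3 and also a step that the two limits leave unreadable from compound 1 to compound 2 with no size to carry over. No step beyond the scatter is therefore expected in this assay for this exchange, and no direction can be assigned.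

For compound 4 the estimate is 30000 nM with an expected range of 14000 nM to 60000 nM and a report as a limit is likely. The expected step is a step that the limit leaves unreadable from compound 3 to compound 4 on this estimate.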

Compound 4, half-maximal cytotoxic concentration: > 24000 nM
Compound 4: only a limit was reported; the forecaster's own chance of this, stated with the estimate: 85%; the middle value does not contradict the limit.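

In this assay compound 4 gives > 24000 nM, a limit. No step from compound 1, compound 2 or compound 3 to compound 4 can be read: the limit of > 24000 nM in this assay, at which 4 of the 4 values shown sit.

The compounds shown leave open whether any of these exchanges, including 5-methyl-1,3,4-oxadiazol-2-yl for 2-methyl-1,3-thiazol-4-yl, changes the result in this assay.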